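The source may hold more compounds than are shown below. What is called first, only, known or untested is meant among the compounds shown, and "the series" means these compounds.

Measured compounds, each known only as a limit:

- compound 1 `Cc1ccc2[nH]c(=O)c(CN(Cc3ccc(F)cc3)Cc3cccc4ccccc34)cc2c1`; in a toxicity assay on MDCK cells (Canis lupus familiaris) for cytotoxicity, read by crystal violet staining, with a stated time of 48 h (a lower number here means that less compound is tolerated, a higher number that more compound is tolerated), compound 1 gives the limit > 5000 nM.
- compound 2 `CCc1ccc2[nH]c(=O)c(CN(Cc3ccc(F)cc3)Cc3cccc4ccccc34)cc2c1`; in this assay compound 2 gives the limit > 5000 nM.
- compound 3 `Cc1ccc2[nH]c(=O)c(CN(Cc3ccc(C(C)(C)C)cc3)[C@H](CO)c3ccccc3)cc2c1`; in this assay compound 3 gives the limit > 10000 nM.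

Compound 1 and compound 2 share one core and differ by methyl in place of hydrogen on a saturated chain carbon bound to an aromatic carbon. The step that the two limits leave unreadable from compound 1 to compound 2 cannot be read, as both ends are limits. Compound 3 carries a different core; the difference between the two cores is not broken down here. Of the three values, two sit at the limit of > 5000 nM in this assay, at which 2 of the 3 values shown sit, and one at the limit of > 10000 nM in this assay, at which 1 of the 3 values shown sits; none is a number.

Compound 4 `CCc1ccc2[nH]c(=O)c(CN(Cc3ccc(C(C)(C)C)cc3)[C@H](CO)c3ccccc3)cc2c1` is compound 3 with methyl in place of hydrogen on a saturated chain carbon bound to an aromatic carbon, the same change at the same place as between compound 1 and compound 2. Because a step that the two limits leave unreadable from compound 1 to compound 2 shows no readable movement, the same change is expected to give only a small step in this assay for compound 4. Compound 4 is expected at 15000 nM, between 8000 nM and 40000 nM, most probably reported again as a limit. The expected step is a step that the limit leaves unreadable from compound 3 to compound 4.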

Compound 4, half-maximal cytotoxic concentration: > 10000 nM
Compound 4: no number, only a limit; the forecaster's own chance of this, stated with the estimate: 85%; the middle value does not contradict the limit.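

In this assay compound 4 gives > 10000 nM, a limit and not a number. Compound 3 gives > 10000 nM, also a limit. Going by these compounds alone, no step from compound 3 to compound 4 can be read. The compounds shown leave open at what concentration any of the four turns cytotoxic, and whether methyl in place of hydrogen shifts that concentration at all.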